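This account rests on a few compounds, and the source may have more. Where it says the series, first, only, none or still open, it means among the compounds named here.

Compound 1 `Cc1ccccc1-n1cc(COc2cccc(NC(=O)Nc3ccc(Cl)c(C(F)(F)F)c3)c2)nn1` gives 3440 nM in a functional assay on HepG2 cells (Homo sapiens) for inhibition, read by MTT assay, with a stated time of 72 h; a higher number here means a weaker inhibitor, a lower number a stronger inhibitor. Compound 2 `N#Cc1ccccc1-n1cc(COc2cccc(NC(=O)Nc3ccc(Cl)c(C(F)(F)F)c3)c2)nn1` gives 1970 nM in the same assay, and compound 3 `N#Cc1ccc(-n2cc(COc3cccc(NC(=O)Nc4ccc(Cl)c(C(F)(F)F)c4)c3)nn2)cc1` gives 2980 nM. Among these three numbers compound 3 holds the second highest place, but its nearest neighbour is compound 1, with a 1.2-fold lower number from compound 1 to compound 3 (0.06 log units; within the scatter), and its furthest is compound 2, with a 1.5-fold higher number from compound 2 to compound 3 (0.18 log units; within the scatter); neither gap exceeds the scatter, so the three compounds cannot be ordered.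

Compound 4 `O=C(Nc1cccc(OCc2cn(-c3ccccc3Cl)nn2)c1)Nc1ccc(Cl)c(C(F)(F)F)c1` has not yet been measured. It differs from compound 3 by 2-chlorophenyl in place of 4-cyanophenyl on an aromatic nitrogen. The group that leaves carries a triple bond and one hydrogen-bond acceptor; the group that enters carries neither.

For the measured compounds named here, the steps that bear on this change are those that alter the ring on the aromatic nitrogen: a 1.2-fold lower number from compound 1 to compound 3 (0.06 log units; within the scatter) and a 1.5-fold higher number from compound 2 to compound 3 (0.18 log units; within the scatter), and also a 1.7-fold lower number from compound 1 to compound 2 (0.24 log units; within the scatter). All three are within the scatter. Compound 4 is therefore expected to show no step beyond the scatter, a 1.0-fold higher number from compound 3 to compound 4 (0.00 log units; within the scatter). The value of compound 4 in this assay is estimated at 3000 nM, with a range from 1500 nM to 6000 nM.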

Compound 4, half-maximal inhibitory concentration: 1960 nM
Beside the measured number, compound 4's estimate is 1.5-fold (0.18 log units) above it; low and high end bracket the measured number.
By their numbers in this assay, from the lowest: compounds 4, 2, 3 and 1 (each within the scatter of the next).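

In this assay chloro on the ring carried by the aromatic nitrogen reads like the groups already seen there, with a 1.5-fold lower number from compound 3 to compound 4 (0.18 log units; within the scatter) for 2-chlorophenyl in place of 4-cyanophenyl, a 1.0-fold lower number from compound 2 to compound 4 (0.00 log units; within the scatter) for chloro in place of cyano and a 1.8-fold lower number from compound 1 to compound 4 (0.24 log units; within the scatter) for chloro in place of methyl. This adds a halogen to the methyl and cyano groups on this ring, and it shows that giving up both the triple bond and the hydrogen-bond acceptor of 4-cyanophenyl leaves no step beyond the scatter. No measurement here accounts for why these groups read alike.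

From the compounds shown here alone, whether a group of another kind on this ring, such as an amine or a carboxylic acid, would move the number beyond the scatter remains open. Also open, going by these compounds, is how 4-chlorophenyl would read against 2-chlorophenyl.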